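This account rests on a few compounds, and the source may have more. Where it says the series, first, only, none or still open, it means among the compounds named here.

Going by the values given here, in an in vitro ADME assay on microsomes from liver (Homo sapiens) for metabolic stability, tested at 5 uM (on this read-out lower numbers stand for a shorter-lived compound and higher numbers for a longer-lived compound), compound 2 `COCN(c1ccc2c(c1)S(=O)(=O)N=C(c1c(O)c(-c3cccs3)nn(CCC(C)C)c1=O)N2)S(C)(=O)=O` gives 0.183 h, the only actual number so far. Compound 1 `CC(C)CCn1nc(-c2cccs2)c(O)c(C2=NS(=O)(=O)c3cc(NS(=O)(=O)C4CC4)ccc3N2)c1=O` reads > 1 h, which is a limit. Compound 3 `CC(C)CCn1nc(-c2cccs2)c(O)c(C2=NS(=O)(=O)c3cc(S(C)(=O)=O)ccc3N2)c1=O` carries methylsulfonyl in place of (methoxymethyl)(methylsulfonyl)amino on an aromatic carbon. Among the compounds with values here, the departing group entered in the one measured step, an at least 5.4-fold lower number from compound 1 to compound 2 (0.73 log units; beyond the scatter), beyond the scatter, so a longer half-life is expected on its removal, though compound 3 does not regain the group of compound 1. The step is estimated as a 4.9-fold higher number from compound 2 to compound 3 (0.69 log units; beyond the scatter). For compound 3 the expected value is 0.9 h, with an estimated range of 0.3 h to 3 h.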

Compound 3, half-life: 0.0933 h
Compound 3: middle estimate off by 9.6-fold (0.98 log units), on the high side; measured number outside the range, below it.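

In this assay, methylsulfonyl in place of (methoxymethyl)(methylsulfonyl)amino gives a 2.0-fold lower number from compound 2 to compound 3 (0.29 log units; within the scatter), so this change separates the two compounds by no more than the usual scatter. Methylsulfonyl in place of (cyclopropylsulfonyl)amino gives an at least 10-fold lower number from compound 1 to compound 3 (1.03 log units; beyond the scatter), so among these three compounds the longer half-life is seen only with (cyclopropylsulfonyl)amino at this position. The reading for compound 1 is a limit: the limit of > 1 h in this assay, at which 1 of the 3 values shown sits.

Going by these compounds, the full size of the gap to compound 1 stays open. Also open, on these data alone, is how (methylsulfonyl)amino without the methoxymethyl, or a simple amine, would read on this aromatic carbon.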